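Removing the sulfamoyl group from an aziridine urea

A few compounds are considered here, and "the series" means these few. Any claim that something is new, unique, unknown or untested is made for them only; others in the source may bear on it.

The measured compounds, in a functional assay on MCF7 cells (Homo sapiens) for inhibition; on this read-out higher numbers stand for weaker inhibition and lower numbers for stronger inhibition:
Compound 1, `N#CC1CN1C(=O)Nc1ccc(Cl)c(Cl)c1`, gives 4600 nM.
Compound 2, `N#CC1CN1C(=O)NCc1ccccc1`, gives 7400 nM.
Compound 3, `N#CC1CN1C(=O)Nc1ccc(S(N)(=O)=O)cc1`, gives > 15000 nM, which is a limit of this assay and not a number.

The three compounds share a cyanoaziridine urea core and differ in the group on the urea nitrogen. Among the numbers shown, compound 3 stands at the weak end: for it only a limit is known, (the limit of > 15000 nM in this assay, at which 1 of the 3 values shown sits), so the gap between compound 3 and compound 1 or compound 2 cannot be sized from these data alone.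

Compound 4, `N#CC1CN1C(=O)Nc1ccccc1`, has not yet been measured. It differs from compound 3 in one place: hydrogen in place of sulfamoyl on an aromatic carbon. For the measured compounds named here, no step between measured compounds matches this change, so the expectation rests on where compound 3 sits relative to compound 1 and compound 2. Compound 4 is expected to show stronger inhibition than the limit reached by compound 3, with a step from an at least 1.8-fold lower number from compound 3 to compound 4 (0.27 log units; that floor lies within the scatter), landing near the region of compound 1 and compound 2; the estimate for compound 4 in this assay is 8000 nM, within 3000 nM to 20000 nM.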

Compound 4, half-maximal inhibitory concentration: 2900 nM
Beside the measured number, compound 4's estimate is 2.8-fold (0.44 log units) above it; the whole stated range lies above it.
By their numbers in this assay, from the lowest: compounds 4, 1 and 2 (each within the scatter of the next, the first and the last beyond it). At a limit, above all of these: compound 3.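

In this assay, for the compounds shown here, hydrogen in place of sulfamoyl on the aromatic carbon para to a group of 8 heavy atoms gives an at least 5.1-fold lower number from compound 3 to compound 4 (0.71 log units; beyond the scatter), the first change at this position that can be sized, since the earlier compounds offered no pair differing in one place. For compound 3, > 15000 nM is a limit of the assay and not a number. The step is therefore only a floor on the change, and its full size cannot be read, because compound 3 stands at that limit: the limit of > 15000 nM in this assay, at which 1 of the 4 values shown sits.

On these data alone, what remains open is whether the weak end belongs to the sulfamoyl group in particular or would follow from other groups on this carbon, a question that a methyl group, an amine or a carboxylic acid at the same place could help to settle. As far as these compounds go, it is also open whether a step of this kind would carry over to other compounds on the shared core, such as a sulfamoyl group added to the phenyl ring of the benzyl group in compound 2.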